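Adding a Ring Methyl to a Cell-Growth Inhibitor

The compounds below may be only part of what the source reports. "The series", "measured", "known", "first", "only" and "open" are said of these compounds alone.

Compound 1 `COc1ccc(N(C)c2nc(N)nc3c2CCC3)cc1` is the reference point of this small set. In a functional assay on MDA-MB-435 cells (Homo sapiens) for inhibition, read by sulforhodamine B assay, with a stated time of 48 h (a higher number here means a weaker inhibitor, a lower number a stronger inhibitor), compound 1 gives 16.7 nM. For the measured compounds named here, compound 2 `COc1ccc(N(C)c2nc(C)nc3c2CCC3)cc1` differs from it by methyl in place of amino on an aromatic carbon; in this assay compound 2 gives 7 nM, and the step of a 2.4-fold lower number from compound 1 to compound 2 (0.38 log units; beyond the scatter) makes compound 2 the one with the lowest number among the three measured compounds. Compound 3 `COc1ccc(N(C)c2nc(N)nc3c2CC(C)C3)cc1` differs from compound 1 by methyl in place of hydrogen on a saturated ring carbon; in this assay compound 3 gives 29.9 nM, a step of a 1.8-fold higher number from compound 1 to compound 3 (0.25 log units; within the scatter).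

Compound 4 `COc1ccc(N(C)c2nc(C)nc3c2C(C)CC3)cc1` has not yet been measured. It differs from compound 2 by methyl in place of hydrogen on a saturated ring carbon, the same change that was made from compound 1 to compound 3, at a place described in the same words. Going by the values given here, only that one earlier instance is available, so the expectation rests on it alone. Compound 4 is expected to show a step of a 1.6-fold higher number from compound 2 to compound 4 (0.20 log units; within the scatter) in this assay, because the same change earlier gave a 1.8-fold higher number from compound 1 to compound 3 (0.25 log units; within the scatter). Compound 4 is therefore estimated at 11 nM in this assay, with a likely range from 5 nM to 25 nM.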

Compound 4, half-maximal inhibitory concentration: 18.8 nM
Beside the measured number, compound 4's estimate is 1.7-fold (0.23 log units) below it; low and high end bracket the measured number.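

In this assay, methyl in place of hydrogen on a saturated ring carbon gives a 2.7-fold higher number from compound 2 to compound 4 (0.43 log units; beyond the scatter), so the number also rises on the core that carries methyl rather than amino on the aromatic carbon. Set beside the earlier step, the change carries over between the two cores in the same direction and with no real difference in size: the same change on two cores in this assay, a 1.8-fold higher number (0.25 log units; within the scatter) from compound 1 to compound 3 and a 2.7-fold higher number (0.43 log units; beyond the scatter) from compound 2 to compound 4, 1.5-fold (0.18 log units) apart, within the scatter of two such steps. Only the newer step lies beyond the scatter on its own, and two pairs of compounds make a consistent picture, not a rule for other cores, and they give no reason for the rise.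

The compounds shown leave open whether an ethyl group, a longer chain or a hydroxyl group in place of that hydrogen would move the number the same way. On these data alone, it is also open how the ring methyl would behave on a core with a chlorine atom or a carboxylic acid in place of the amino or methyl on the aromatic carbon.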